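Hydrogen in place of pyridin-2-yl on a sulfonamide nitrogen

A few compounds are considered here, and "the series" means these few. Any claim that something is new, unique, unknown or untested is made for them only; others in the source may bear on it.

Compound 1 `O=S(=O)(Nc1ncccn1)c1ccc(Nc2nncc3ccccc23)cc1` gives 64 nM
Compound 2 `O=S(=O)(Nc1nccs1)c1ccc(Nc2nncc3ccccc23)cc1` gives 55 nM
Compound 3 `O=S(=O)(Nc1ccccn1)c1ccc(Nc2nncc3ccccc23)cc1` gives 53 nM

All three values come from a functional assay on MCF7 cells (Homo sapiens) for antiproliferative activity, read by sulforhodamine B assay, with a stated time of 72 h (a lower number here means a stronger inhibitor, a higher number a weaker inhibitor), and the compounds differ only in the group on the sulfonamide nitrogen. Compound 3 stands level with the other two, with no separation beyond the scatter. Compound 4 `NS(=O)(=O)c1ccc(Nc2nncc3ccccc23)cc1` has no such group at all. Its change from compound 3 is hydrogen in place of pyridin-2-yl on a sulfonamide nitrogen, counted as hydrogen in place of pyridin-2-yl on a sulfonamide nitrogen in full.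

The steps of a 1.2-fold lower number from compound 1 to compound 2 (0.07 log units; within the scatter) and a 1.2-fold lower number from compound 1 to compound 3 (0.08 log units; within the scatter) and a 1.0-fold lower number from compound 2 to compound 3 (0.02 log units; within the scatter) are the nearest evidence. Each swaps one group for another at that nitrogen, and all are small. Among the compounds with values here, none of them removes the group, so they offer only a weak guide to this change, and no measured step fixes its direction. A moderate step in this assay is therefore expected, with a higher number somewhat more likely than a lower one. Starting from compound 3 at 53 nM as the reference, the estimate is a 1.7-fold higher number from compound 3 to compound 4 (0.23 log units; within the scatter) as the expected step. For compound 4 the estimated value is 90 nM with an expected range from 25 nM to 350 nM in this measurement.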

Compound 4, half-maximal inhibitory concentration: 37 nM
For compound 4 the middle estimate is 2.4-fold (0.39 log units) above the measured one; low and high end bracket the measured number.
By their numbers in this assay, from the lowest: compounds 4, 3, 2 and 1 (each within the scatter of the next).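

In this assay, taking the group off the sulfonamide nitrogen altogether leaves the number within the scatter, as the steps of a 1.4-fold lower number from compound 3 to compound 4 (0.16 log units; within the scatter) and a 1.5-fold lower number from compound 2 to compound 4 (0.17 log units; within the scatter) and a 1.7-fold lower number from compound 1 to compound 4 (0.24 log units; within the scatter) show. The earlier compounds shown here only swapped one ring-bearing group for another, so they could not show what happens with no group there. Now pyridin-2-yl, with its 6 heavy atoms, as well as 1,3-thiazol-2-yl and pyrimidin-2-yl, can each give way to a plain hydrogen while all four compounds stay level, which means none of these groups is needed for a number of this size in this series, and nothing measured here explains why the position accepts this change.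

Still open, from the compounds shown here alone, is whether a small group such as methyl or acetyl on this nitrogen, or a phenyl ring without any hetero atom, would also stay level with these four compounds. Going by these compounds, all four share one core, so it also remains open whether the same holds once an amine or a carboxylic acid is added elsewhere on that core.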